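Swapping Chloro for Bromo on an Indole-Based Calpain Inhibitor

The source may hold more compounds than are shown below. What is called first, only, known or untested is meant among the compounds shown, and "the series" means these compounds.

Three close relatives of one shared core have been tested in an assay on isolated protein for inhibition of Calpain-1 catalytic subunit (Sus scrofa); a lower number here means a stronger inhibitor, a higher number a weaker inhibitor. Compound 1 `O=C(O)/C(S)=C/c1c[nH]c2ccc(Br)cc12` gives 20 nM. Compound 2 `O=C(O)/C(S)=C/c1c[nH]c2cccc(F)c12` gives 300 nM, and compound 3 `O=C(O)/C(S)=C/c1c[nH]c2cccc(Cl)c12` gives 140 nM. Among these three numbers compound 3 stands second highest: its nearest neighbour is compound 2, while compound 1 lies furthest away with a clearly lower number. Compound 1 carries its bromo at a different spot on the core, so its value shows only that a bromo-bearing relative can reach a low number, not what bromo does at the position in question.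

Compound 4 `O=C(O)/C(S)=C/c1c[nH]c2cccc(Br)c12` differs from compound 3 by one exchange: bromo in place of chloro on an aromatic carbon. Among the measured compounds shown here, the only measured step at this very position is a 2.1-fold lower number from compound 2 to compound 3 (0.33 log units; beyond the scatter), where a heavier halogen replaced a lighter one. Continuing in the same direction, from chloro to bromo, a modest further drop is expected, but it could equally land within the scatter. The estimate for compound 4 is therefore 80 nM, with a range from 35 nM to 200 nM, which means an expected step of a 1.8-fold lower number from compound 3 to compound 4 (0.24 log units; within the scatter) in this assay.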

Compound 4, half-maximal inhibitory concentration: 100 nM
For compound 4 the middle estimate is 1.3-fold (0.10 log units) below the measured one, and the stated range covers the measured number.
By their numbers in this assay, from the lowest: compound 1; then compounds 4 and 3 (each within the scatter of the next); then compound 2.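

In this assay, the exchange of chloro for bromo gives a 1.4-fold lower number from compound 3 to compound 4 (0.15 log units; within the scatter), so at this position the two halogens cannot be told apart by this read-out. Only the wider exchange of fluoro for bromo clears the scatter, with a 3.0-fold lower number from compound 2 to compound 4 (0.48 log units; beyond the scatter), and this matches a 2.1-fold lower number from compound 2 to compound 3 (0.33 log units; beyond the scatter): among the three halogens tested at this position, fluoro stands apart, while the drop seen on going to chloro does not clearly continue on to bromo. No measured information is available to explain why these halogens behave this way.

The compounds shown leave open whether any group at this position other than a halogen, such as a methoxy, an amine or a nitrile, would take the number outside the range of these three compounds. From the compounds shown here alone, compound 1 gives 20 nM with its bromo at a different spot on the core, so it also remains open how chloro or fluoro would fare at that other spot.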